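Halogen swap on the aryl ketone of a pyrazolyl chalcone

This account rests on a few compounds, and the source may have more. Where it says the series, first, only, none or still open, it means among the compounds named here.

Three compounds sharing one core were measured in a functional assay on A549 cells (Homo sapiens) for cytotoxicity, read by sulforhodamine B assay, with a stated time of 48 h, tested at 100 uM; on this read-out higher numbers stand for a weaker effect at the one concentration tested and lower numbers for a stronger effect. Compound 1 `COc1ccc(-c2cc(/C=C/C(=O)c3ccc(OC)c(OC)c3)[nH]n2)cc1` gives -45% in this assay. Compound 3 `COc1cc(C(=O)/C=C/c2cc(-c3cc(OC)c(OC)c(OC)c3)n[nH]2)cc(OC)c1OC` gives -66% in this assay. Compound 2 `COc1cc(-c2cc(/C=C/C(=O)c3ccc(Cl)c(Cl)c3)[nH]n2)cc(OC)c1OC` gives 2% in this assay, the highest of the three numbers; compound 1 is its nearest neighbour, a number lower than compound 2 by a margin beyond the scatter, and compound 3 lies furthest from compound 2, also beyond the scatter. Compound 2 thus shows the weakest effect of the three at the concentration tested.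

Compound 4 `COc1cc(-c2cc(/C=C/C(=O)c3ccc(F)c(F)c3)[nH]n2)cc(OC)c1OC` has not yet been measured. It differs from compound 2 in one place: 3,4-difluorophenyl in place of 3,4-dichlorophenyl on a carbonyl carbon. For the measured compounds named here, no step between measured compounds matches this change, so nothing in the data fixes its size. The author expects a modest step downward, likely not clearly beyond the scatter, from compound 2 to compound 4 of a number 12 percentage points lower from compound 2 to compound 4 (beyond the scatter). Compound 4 is therefore estimated at -10% in this assay, within a range from -45% to 20%.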

Compound 4, a percentage reported as activity, at one concentration (the size of the read-out at that concentration, not a potency): -15%
For compound 4 the middle estimate is 5 percentage points above the measured one; measured number inside the range.
By their numbers in this assay, from the lowest: compound 3; then compound 1; then compound 4; then compound 2.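

In this assay, the series now holds its first step at a single place: a number 17 percentage points lower from compound 2 to compound 4 (beyond the scatter), with 3,4-difluorophenyl in place of 3,4-dichlorophenyl on a carbonyl carbon. The read-out at this position therefore responds to the identity of the halogen alone, since the rest of the molecule and the heavy-atom count of the group stay the same, and the change runs towards a stronger effect at the concentration tested. Nothing available here accounts for the size or direction of this step.

On these data alone, it remains open where a phenyl bearing no halogen, a 3,4-dibromophenyl or a 4-aminophenyl on the same carbonyl carbon would fall relative to these two compounds. Also open, as far as these compounds go, is whether the same halogen swap gives a comparable step with a different pattern of methoxy groups on the shared core.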